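The source may hold more compounds than are shown below. What is called first, only, known or untested is meant among the compounds shown, and "the series" means these compounds.

Within the data shown here, compound 1 `Nc1cc(N)c2nc(-c3ccccc3)c(NCc3ccc(Cl)c(Cl)c3)nc2c1` is the one compound of this set for which a number rather than a limit exists in a functional assay on MCF7 cells (Homo sapiens) for inhibition, read by sulforhodamine B assay, with a stated time of 48 h; on this read-out lower numbers stand for stronger inhibition of growth and higher numbers for weaker inhibition of growth. In this assay compound 1 gives 53700 nM, which makes it the only fixed point among the values shown. Compound 2 `CCOC(=O)[C@H](CCC(=O)O)NC(=O)c1ccc(Oc2nc3cc(N)cc(N)c3nc2-c2ccccc2)cc1` carries the same core with a different group on the nitrogen side, and in this assay compound 2 gives < 100000 nM, a value that is a limit of the assay and not a number, as noted at the limit of < 100000 nM in this assay, at which 1 of the 2 values shown sits.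

Compound 3 `COc1ccc(CNc2nc3cc(N)cc(N)c3nc2-c2ccccc2)cc1` is not yet measured. It differs from compound 1 in one place: 4-methoxyphenyl in place of 3,4-dichlorophenyl on a saturated chain carbon bound to a nitrogen on an aromatic ring. No measured pair in this set shares that change, so the size of the step cannot be read from any shown step; it has to be expected. Given the single fixed number of compound 1 at 53700 nM, the step is expected to stay within the usual scatter of this assay, in no settled direction, so that the estimated step is a 1.1-fold lower number from compound 1 to compound 3 (0.03 log units; within the scatter). On that basis compound 3 is estimated at 50000 nM in this assay, with a range from 15000 nM to 150000 nM.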

Compound 3, concentration for total growth inhibition: 26300 nM
The estimate for compound 3 lay 1.9-fold (0.28 log units) above the measured number; low and high end bracket the measured number.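

In this assay, the group on a saturated chain carbon bound to a nitrogen on an aromatic ring now has its first measured step: a 2.0-fold lower number from compound 1 to compound 3 (0.31 log units; beyond the scatter) comes with 4-methoxyphenyl in place of 3,4-dichlorophenyl. The position therefore responds, if modestly, to an exchange of one aryl group for another of the same heavy-atom count, in which both chlorine atoms leave and one hydrogen-bond acceptor enters. No measurement among those shown speaks to why the number moves with this change.

Among these compounds, the single pair leaves open whether the lower number goes with the loss of the chlorine atoms or with the gain of the methoxy group; an unsubstituted phenyl or a 4-chlorophenyl at the same place would separate the two. Also open, on these data alone, is how the number would respond to a longer chain between the nitrogen and the ring, or to an amine or a carboxylic acid on that ring in place of the methoxy group.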